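A few compounds are considered here, and "the series" means these few. Any claim that something is new, unique, unknown or untested is made for them only; others in the source may bear on it.

Clearance figures in an ADME assay on the whole organism (Mus musculus, strain CD1) for pharmacokinetics, read by LC-MS, using cassette dosing, with a stated time of 24 h, at a dose of 0.4 mg/kg by the intravenous route (a lower number here means slower removal, a higher number faster removal of the compound), for the three measured members of the series:

compound 1 `Cc1cn(-c2cc(NC(=O)c3ccc(C)c(Oc4ccccc4)c3)cc(C(F)(F)F)c2)cn1`: 12.5 mL/min/kg
compound 2 `Cc1cn(-c2cc(NC(=O)c3ccc(C)c(Oc4ccccc4)c3)cc(N3CCN(C)CC3)c2)cn1`: 17.5 mL/min/kg
compound 3 `Cc1cn(-c2cc(NC(=O)c3ccc(C)c(C(=O)c4cccc(C#N)c4)c3)cc(N3CCN(C)CC3)c2)cn1`: 81 mL/min/kg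

Compound 2 holds the second highest of the three numbers. Its nearest neighbour is compound 1, with a 1.4-fold higher number from compound 1 to compound 2 (0.15 log units; within the scatter), a difference that is within the scatter; the furthest is compound 3, with a 4.6-fold higher number from compound 2 to compound 3 (0.67 log units; beyond the scatter), beyond the scatter.

Compound 4 `Cc1cn(-c2cc(CN3CCC[C@H](N)C3)cc(NC(=O)c3ccc(C)c(Oc4ccccc4)c3)c2)cn1` has not yet been measured. It differs from compound 2 in one place: (3-aminopiperidin-1-yl)methyl in place of 4-methylpiperazin-1-yl on an aromatic carbon.

Going by the values given here, of the two measured steps, only the one from compound 1 to compound 2 touches the same place on the core, and there the number moved by a 1.4-fold higher number from compound 1 to compound 2 (0.15 log units; within the scatter), within the scatter. The step from compound 2 to compound 3 alters a different part of the molecule and does not bear directly on this exchange. Among the compounds with values here, no measured compound carries a (3-aminopiperidin-1-yl)methyl group, so the comparison rests on a single step at this place.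

On that basis no step beyond the scatter is expected in this assay from compound 2 to compound 4; the expected step is a 1.0-fold higher number from compound 2 to compound 4 (0.01 log units; within the scatter). Compound 4 is therefore estimated at 18 mL/min/kg, with a range from 9 mL/min/kg to 36 mL/min/kg.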

Compound 4, clearance: 5 mL/min/kg
Estimate against measurement, compound 4: 3.6-fold (0.56 log units) above; measured number below the stated range.
By their numbers in this assay, from the lowest: compound 4; then compounds 1 and 2 (each within the scatter of the next); then compound 3.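

In this assay this place, meta to the 4-methyl-1H-imidazol-1-yl group, can shift clearance beyond the scatter (here a 3.5-fold lower number from compound 2 to compound 4 (0.54 log units; beyond the scatter) and a 2.5-fold lower number from compound 1 to compound 4 (0.40 log units; beyond the scatter)), whereas the earlier exchange of trifluoromethyl for 4-methylpiperazin-1-yl stayed within it (a 1.4-fold higher number from compound 1 to compound 2 (0.15 log units; within the scatter)). The change from 4-methylpiperazin-1-yl to (3-aminopiperidin-1-yl)methyl alters several things at once: 1 hydrogen-bond donor against 0, a ring with 1 hetero atom against 2, a methyl-linked attachment and 1 defined stereocentre, and these compounds do not separate their contributions to the lower number. Nothing available explains why clearance falls with this group.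

As far as these compounds go, it remains open whether the lower number follows the primary amine, the carbon link to the aromatic ring or the stereocentre; (4-methylpiperazin-1-yl)methyl, 3-hydroxypiperidin-1-ylmethyl and the opposite enantiomer of the 3-aminopiperidine would each address one of these. Also open, from the compounds shown here alone, is whether the effect of this group carries over when (3-cyanophenyl)carbonyl replaces phenoxy on the other side of the amide.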